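Ethoxy in place of trifluoromethyl: solubility at acidic pH

This account rests on a few compounds, and the source may have more. Where it says the series, first, only, none or still open, it means among the compounds named here.

Compound 1, `COc1ccc(-c2cc(-c3ccc(S(C)(=O)=O)cc3)cnc2NCCCCN)cn1`, in a physicochemical assay for solubility, measured as kinetic solubility, at pH 2 (a higher number here means a more soluble compound, a lower number a less soluble compound), gives a value that is a limit of the assay, > 100 ug/mL.
Compound 2, `COc1ccc(-c2cc(-c3ccc(S(C)(=O)=O)cc3)cnc2O)cn1`, gives 25 ug/mL in this assay.
Compound 3, `COc1ccc(-c2cc(-c3ccc(S(C)(=O)=O)cc3)cnc2C(F)(F)F)cn1`, gives 12.5 ug/mL in this assay.

Compound 3 sits lowest of the two numbers shown; its nearest neighbour is compound 2, and the gap a 2.0-fold lower number from compound 2 to compound 3 (0.30 log units; within the scatter) is within the scatter. The value of compound 1 is a limit only (the limit of > 100 ug/mL in this assay, at which 1 of the 3 values shown sits).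

The unmeasured compound 4, `CCOc1ncc(-c2ccc(S(C)(=O)=O)cc2)cc1-c1ccc(OC)nc1`, departs from compound 3 by ethoxy in place of trifluoromethyl on an aromatic carbon. Among the measured compounds shown here, no measured step swaps an ethoxy group, so the bearing steps are indirect: an at least 4.0-fold lower number from compound 1 to compound 2 (0.60 log units; beyond the scatter) and an at least 8.0-fold lower number from compound 1 to compound 3 (0.90 log units; beyond the scatter) both start from a limit and show only that the (4-aminobutyl)amino group sits far above the other two groups, while a 2.0-fold lower number from compound 2 to compound 3 (0.30 log units; within the scatter) places hydroxy and trifluoromethyl within the scatter of each other. An ethoxy group is neither of these, and the data give no reason to expect a change beyond the scatter in this assay. Compound 4 is therefore expected to give about 20 ug/mL, within 6 ug/mL to 60 ug/mL, which corresponds to an expected step of a 1.6-fold higher number from compound 3 to compound 4 (0.20 log units; within the scatter).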

Compound 4, solubility: 1.6 ug/mL
For compound 4 the middle estimate is 13-fold (1.10 log units) above the measured one, and the stated range ends above it.
By their numbers in this assay, from the lowest: compound 4; then compounds 3 and 2 (each within the scatter of the next). At a limit, above all of these: compound 1.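

At this aromatic carbon next to the ring nitrogen, the earlier compounds had shown only that hydroxy and trifluoromethyl stand within the scatter of each other in this assay, and ethoxy breaks from that pair, with a 7.8-fold lower number from compound 3 to compound 4 (0.89 log units; beyond the scatter). The change from hydroxy to ethoxy adds only an ethyl on the oxygen, yet it gives a 16-fold lower number from compound 2 to compound 4 (1.19 log units; beyond the scatter), so a small change at this position separates two compounds clearly, and compound 4 now stands below all the others, each by a step beyond the scatter. The widest span shown, an at least 62-fold lower number from compound 1 to compound 4 (1.79 log units; beyond the scatter), starts from a value that is a limit: the limit of > 100 ug/mL in this assay, at which 1 of the 4 values shown sits.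

The compounds shown do not tell whether the ethyl alone carries this step, or whether a methoxy group or a longer alkoxy chain at the same carbon would stay near compound 4 or return towards compound 2. They also leave open whether the high end of the series needs the full (4-aminobutyl)amino chain with its terminal amine, or whether a shorter amine or a simple dimethylamino group at this carbon would reach the same region in this assay.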